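The source may hold more compounds than are shown below. What is called first, only, known or untested is meant among the compounds shown, and "the series" means these compounds.

In an ADME assay on A549 cells (Homo sapiens) for cytotoxicity, read by CellTiter-Glo (a lower number here means that less compound is tolerated, a higher number that more compound is tolerated), compound 1 (`Cc1c(Cc2ccccc2)c(=O)oc2cc(OCC(O)CNc3ccccc3)ccc12`) gives > 100000 nM as its reading, and that reading is a limit of the assay, not a number. Within the data shown here, compound 2 (`Cc1c(Cc2ccccc2)c(=O)oc2cc(OCC(O)CNc3nccs3)ccc12`) gives 93000 nM as its reading, the only true number so far. Among the measured compounds shown here, the one measured step is an at least 1.0-fold lower number from compound 1 to compound 2 (0.03 log units; that floor lies within the scatter) and it puts 1,3-thiazol-2-yl in place of phenyl on an amine nitrogen.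

Compound 3 (`Cc1c(Cc2ccccc2)c(=O)oc2cc(OCCCNc3nccs3)ccc12`) keeps the 1,3-thiazol-2-yl group and differs from compound 2 elsewhere: hydrogen in place of hydroxy on a saturated chain carbon bound to two saturated chain carbons is the change, with hydrogen in place of hydroxy on a saturated chain carbon bound to two saturated chain carbons. For the measured compounds named here, the one measured step changed a different place, so it gives no size for this change. With no measured guide, no shift beyond the scatter is expected in this assay and a reading at the limit of the assay remains possible. The estimated step is a 1.3-fold lower number from compound 2 to compound 3 (0.12 log units; within the scatter) at its middle value. For compound 3 the expected value is 70000 nM with a range from 30000 nM to 100000 nM as the estimate.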

Compound 3, half-maximal cytotoxic concentration: 50100 nM
Compound 3: the middle estimate sits 1.4-fold (0.15 log units) above what was measured; measured number inside the range.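

Among these compounds, this is the first measured look at the hydroxy group on the chain. In this assay putting hydrogen in its place gives a 1.9-fold lower number from compound 2 to compound 3 (0.27 log units; within the scatter) and so, on this saturated chain carbon, the hydroxy group can go without the reading leaving the usual scatter. The wider change, which swaps 2-anilino-1-hydroxyethyl for 2-((1,3-thiazol-2-yl)amino)ethyl, gives an at least 1.9-fold lower number from compound 1 to compound 3 (0.30 log units; that floor lies within the scatter) and this figure is only a floor, which also lies within the scatter, because the reading for compound 1 is a limit and not a number: the limit of > 100000 nM in this assay, at which 1 of the 3 values shown sits.

Still open, going by these compounds, is whether the hydroxy group counts for as little when phenyl, rather than 1,3-thiazol-2-yl, sits on the amine nitrogen, since only the thiazole pair gives a comparison at this carbon. Also open, on these data alone, is how the reading responds to other groups at this place, such as a methoxy group, a fluorine or an amine on the same carbon, or to a longer chain between the core and the amine nitrogen.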